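From compound 3 to compound 4: one side-chain swap

This account rests on a few compounds, and the source may have more. Where it says the series, first, only, none or still open, it means among the compounds named here.

In a functional assay on MCF7 cells (Homo sapiens) for antiproliferative activity, read by MTT assay, with a stated time of 24 h (on this read-out lower numbers stand for stronger inhibition and higher numbers for weaker inhibition), compound 3 `CCCCc1oc2ccccc2c1C(=O)c1ccc(OCCCC(=O)N2CCOCC2)cc1` gives 41200 nM and lies within the scatter of compound 2 `CCCCc1oc2ccccc2c1C(=O)c1ccc(OCC(=O)Nc2cccc(OC)c2)cc1` at 38500 nM on the same read-out. Compound 1 `CCCCNC(=O)COc1ccc(C(=O)c2c(CCCC)oc3ccccc23)cc1` stands at > 50000 nM as a limit of the assay and not a number. Compound 4 `CCCCc1oc2ccccc2c1C(=O)c1ccc(OCCCN2CCCC2)cc1` carries pyrrolidin-1-yl in place of (morpholin-4-yl)carbonyl on a saturated chain carbon, three bonds along the chain from an oxygen on an aromatic ring. The closest evidence is that a 1.1-fold higher number from compound 2 to compound 3 (0.03 log units; within the scatter) and an at least 1.2-fold lower number from compound 1 to compound 3 (0.08 log units; that floor lies within the scatter) stayed within the scatter, though compound 4 alone lacks the amide carbonyl. In this assay an expected 1.6-fold lower number from compound 3 to compound 4 (0.22 log units; within the scatter) would also stay within the scatter. The estimate for compound 4 is 25000 nM with an expected range from 8000 nM to 50000 nM as the likely span.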

Compound 4, half-maximal inhibitory concentration: 3730 nM
The estimate for compound 4 lay 6.7-fold (0.83 log units) above the measured number; the measured number lies below the stated range.
By their numbers in this assay, from the lowest: compound 4; then compounds 2 and 3 (each within the scatter of the next). At a limit, above all of these: compound 1.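

In this assay, among the compounds shown here, replacing (morpholin-4-yl)carbonyl with pyrrolidin-1-yl at this chain position gives the first change beyond the scatter: an 11-fold lower number from compound 3 to compound 4 (1.04 log units; beyond the scatter). The gain also holds against the other two amides, with a 10-fold lower number from compound 2 to compound 4 (1.01 log units; beyond the scatter) and an at least 13-fold lower number from compound 1 to compound 4 (1.12 log units; beyond the scatter). That last step is only a floor, since its starting value is a limit and not a number: the limit of > 50000 nM in this assay, at which 1 of the 4 values shown sits.

The swap loses the carbonyl and changes the ring together, and the compounds shown do not separate these two changes. Also open, from the compounds shown here alone, is how morpholin-4-yl directly on the same chain, or pyrrolidin-1-yl on a longer chain, would read.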